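Acylating the ring nitrogen of compound 1

The source may report more compounds than this note shows. Statements on the series, on what has been measured and on what is new or still open speak of the compounds shown alone.

Compound 1, `CCCCNc1nc(N)nc2c1CNCC2`: 7.2 uM
Compound 2, `CCCCNc1nc(N)nc2c1CCN(S(C)(=O)=O)C2`: 0.8 uM

In an assay on HEK293 cells for agonist activity at Toll-like receptor 8 (Homo sapiens), read by a luciferase reporter, with a stated time of 6 h (a lower number here means that less compound is needed, a higher number that more compound is needed for the effect), compound 1 gives 7.2 uM, the highest of the two numbers recorded, while compound 2 gives 0.8 uM, a gap beyond the scatter. Compound 3, `CCCCNc1nc(N)nc2c1CN(C(=O)c1csnn1)CC2`, has not yet been measured. It differs from compound 1 by (1,2,3-thiadiazol-4-yl)carbonyl in place of hydrogen on an amine nitrogen in a ring. Compound 2 shows that a substituent on the ring amine nitrogen can go with a lower number, so a step downward is expected, from compound 1 to compound 3 of about a 4.8-fold lower number from compound 1 to compound 3 (0.68 log units; beyond the scatter). Compound 3 is thus estimated at 1.5 uM, within 0.4 uM to 6 uM.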

Compound 3, minimum effective concentration: 0.1 uM
Compound 3: middle estimate off by 15-fold (1.18 log units), on the high side, and the stated range ends above it.
By their numbers in this assay, from the lowest: compound 3; then compound 2; then compound 1.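

Placing (1,2,3-thiadiazol-4-yl)carbonyl on the amine nitrogen in the ring gives a 72-fold lower number from compound 1 to compound 3 (1.86 log units; beyond the scatter) in this assay and counts as a large step. This shows that the ring nitrogen of compound 1 accepts an acyl group bearing a five-membered aromatic ring, and that the free hydrogen there is not needed for the effect. Still open, from the compounds shown here alone, is whether the carbonyl alone carries this step or the thiadiazole ring is needed as well. An acetyl group or a benzoyl group on the same nitrogen would separate the two. No measurement at hand explains the size of this step.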